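Replacing Phenyl with Quinolin-6-yl on the Carbonyl Carbon

The source may hold more compounds than are shown below. What is called first, only, known or untested is meant among the compounds shown, and "the series" means these compounds.

Compound 1 `CC1(C)c2[nH]nc(NC(=O)c3ccccc3)c2CN1Cc1cc(F)cc(F)c1` was tested in an assay on Sf21 cells for inhibition of high affinity nerve growth factor receptor (Homo sapiens), read by HTRF, with a stated time of 30 min, in the presence of a further agent that is not named here (on this read-out higher numbers stand for weaker inhibition and lower numbers for stronger inhibition), where compound 1 gives 190 nM. Compound 2 `CC1(C)c2[nH]nc(NC(=O)c3ccccc3)c2CN1Cc1cccc(F)c1F` differs only at the group on the saturated chain carbon bound to the ring amine nitrogen; in this assay compound 2 gives 200 nM, and the step of a 1.1-fold higher number from compound 1 to compound 2 (0.02 log units; within the scatter) lies within the scatter, so the two values cannot be told apart. Compound 3 `CC1(C)c2[nH]nc(NC(=O)c3ccc4ncccc4c3)c2CN1Cc1cc(F)cc(F)c1` keeps the 3,5-difluorophenyl group of compound 1 and alters the amide instead: quinolin-6-yl in place of phenyl on a carbonyl carbon. For the measured compounds named here, no measured step touches that part of the molecule; the single step available concerns the other end and was within the scatter, so it offers no guide to direction or size here. Compound 3 is therefore expected to sit close to its parent, with an estimated step of a 1.6-fold lower number from compound 1 to compound 3 (0.20 log units; within the scatter) that the data cannot anchor. The estimate for compound 3 is 120 nM, within a range from 20 nM to 700 nM.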

Compound 3, half-maximal inhibitory concentration: 180 nM
The estimate for compound 3 lay 1.5-fold (0.18 log units) below the measured number; the range from low to high includes it.
By their numbers in this assay, from the lowest: compounds 3, 1 and 2 (each within the scatter of the next).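

In this assay, for the compounds shown here, the change of phenyl to quinolin-6-yl on a carbonyl carbon gives a 1.1-fold lower number from compound 1 to compound 3 (0.02 log units; within the scatter) and is the first step read at this position. It shows that this position accepts quinolin-6-yl, with 10 heavy atoms and 1 hydrogen-bond acceptor, in place of phenyl, with 6 heavy atoms and 0 hydrogen-bond acceptors, without a step beyond the scatter. No supporting data bear on this result.

The compounds shown leave open whether a methyl group or a phenyl carrying a piperazine on the carbonyl carbon would give a step beyond the scatter. They also leave open whether quinolin-6-yl would give a similar number in a compound carrying 2,3-difluorophenyl.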